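Methyl for fluoro on the anilino ring of compound 3

This account rests on a few compounds, and the source may have more. Where it says the series, first, only, none or still open, it means among the compounds named here.

Three ureas on one shared core have been run in a functional assay on NCI-H226 cells (Homo sapiens) for inhibition, read by MTT assay, with a stated time of 48 h, tested at 10 uM; on this read-out higher numbers stand for more inhibition at the one concentration tested (going by the name of the read-out) and lower numbers for less inhibition. Compound 1 `CCc1ccc(Nc2cc(NC(=O)Nc3c(Cl)cccc3Cl)ncn2)cc1` gives 39.5% in this assay. Compound 2 `COc1cc(Br)ccc1Nc1cc(NC(=O)Nc2c(Cl)cccc2Cl)ncn1` gives 43% in this assay. Compound 3 `COc1cc(NC(=O)Nc2cc(Nc3ccc(C)c(F)c3)ncn2)cc(OC)c1` gives 39.7% in this assay. All three numbers sit within the usual scatter of one another: the gap between compound 3 and compound 1 is within the scatter, and the gap between compound 3 and compound 2 is within the scatter, so these figures do not separate the three compounds.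

Going by the values given here, the only single-point step measured so far is a number 3.5 percentage points higher from compound 1 to compound 2 (within the scatter), a swap of the whole aryl group on the nitrogen of the shared core, and it stays within the scatter.

Compound 4 `COc1cc(NC(=O)Nc2cc(Nc3ccc(C)c(C)c3)ncn2)cc(OC)c1` differs from compound 3 by methyl in place of fluoro on an aromatic carbon. Among the compounds with values here, no measured step exchanges fluoro for methyl, so the bearing of the one measured step is loose: it concerns the same nitrogen-borne aryl ring, with a much larger swap, and moved nothing beyond the scatter. A step of a number 0.3 percentage points higher from compound 3 to compound 4 (within the scatter) is therefore expected, meaning no move beyond the scatter. Compound 4 is estimated at 40% in this assay, with a range from 28% to 52%.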

Compound 4, a percentage reported as inhibition, at one concentration (the size of the read-out at that concentration, not a potency): 45.3%
Beside the measured number, compound 4's estimate is 5.3 percentage points below it; the range from low to high includes it.
By their numbers in this assay, from the lowest: compounds 1, 3, 2 and 4 (each within the scatter of the next).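

In this assay, the exchange of 3-fluoro-4-methylphenyl for 3,4-dimethylphenyl on the amino nitrogen gives a number 5.6 percentage points higher from compound 3 to compound 4 (within the scatter). Going by these compounds alone, this is the only measured step at this aromatic carbon, ortho to a methyl group, and unlike the whole-group swap in the earlier step, it exchanges one heavy atom for one heavy atom, with no ring, hydrogen-bond donor or acceptor, or net charge entering or leaving, yet it still does not separate the two compounds at the one concentration tested. No supporting data bear on how this step should be read, so it stands as a bare observation on a single pair.

Still open is whether a different group on this aromatic carbon, such as an amine, a carboxylic acid or a longer chain such as propyl, would give a step beyond the scatter, since fluoro and methyl are the only two groups shown here. Also open, from the compounds shown here alone, is whether the same fluoro-to-methyl exchange would read alike on a urea carrying the other aryl group seen in compound 1, or at other concentrations.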